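A few compounds are considered here, and "the series" means these few. Any claim that something is new, unique, unknown or untested is made for them only; others in the source may bear on it.

Measured in an ADME assay on MRC5 cells (Homo sapiens) for cytotoxicity, read by fluorescence, with a stated time of 24 h; a higher number here means a weaker inhibitor, a lower number a stronger inhibitor:
- Compound 1 `CC1S/C(=N\N=C\c2c(-c3ccc(Br)cc3)[nH]c3ccccc23)NC1=O`: > 50000 nM, a limit of the assay
- Compound 2 `O=C1N/C(=N/N=C/c2c(-c3ccc(Br)cc3)[nH]c3ccccc23)SC1CCO`: 15900 nM
- Compound 3 `CCC1S/C(=N\N=C\c2c(-c3ccc(Br)cc3)[nH]c3ccccc23)NC1=O`: 5910 nM

Compound 2 holds the higher of the two exact numbers, 15900 nM, and its nearest neighbour lies at a 2.7-fold lower number from compound 2 to compound 3 (0.43 log units; beyond the scatter). Compound 4 `O=C1N/C(=N/N=C/c2c(-c3ccc(Cl)cc3)[nH]c3ccccc23)SC1CCO` differs from it in one place: chloro in place of bromo on an aromatic carbon, 4-bromophenyl to 4-chlorophenyl. Going by the values given here, no measured step touches this halogen. Both an at least 3.1-fold lower number from compound 1 to compound 2 (0.49 log units; beyond the scatter) and an at least 8.4-fold lower number from compound 1 to compound 3 (0.92 log units; beyond the scatter) alter the saturated chain, as does the step to compound 3. They give no size for this change, so no shift beyond the scatter is expected in this assay. The expected result is a 1.1-fold higher number from compound 2 to compound 4 (0.03 log units; within the scatter). Compound 4 is estimated at 17000 nM, within a range of 8000 nM to 38000 nM.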

Compound 4, half-maximal inhibitory concentration: 13200 nM
Compound 4: middle estimate off by 1.3-fold (0.11 log units), on the high side; low and high end bracket the measured number.
By their numbers in this assay, from the lowest: compound 3; then compounds 4 and 2 (each within the scatter of the next). At a limit, above all of these: compound 1.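

In this assay, the only step shown at this halogen, 4-bromophenyl to 4-chlorophenyl, gives a 1.2-fold lower number from compound 2 to compound 4 (0.08 log units; within the scatter). With the chain of compound 2, this aromatic carbon thus carries chloro or bromo without a shift beyond the scatter, whereas a change in the saturated chain gives a 2.7-fold lower number from compound 2 to compound 3 (0.43 log units; beyond the scatter). Compound 1 alone stands at a limit, and this pair does not touch it: the limit of > 50000 nM in this assay, at which 1 of the 4 values shown sits.

On these data alone, whether chloro behaves the same way with the chains of compound 1 and compound 3 remains open. So does the outcome with fluoro, methoxy or an amine on this carbon.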